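A few compounds are considered here, and "the series" means these few. Any claim that something is new, unique, unknown or untested is made for them only; others in the source may bear on it.

Measured compounds:

- compound 1, `CCCCN(c1nc2c(C(=O)O)cccc2o1)[C@H](C)c1ccc(-c2ccccc2-c2nnn[nH]2)cc1`: 0.000285
- compound 2, `CCCCN(c1nc2c(C(=O)NC)cccc2o1)[C@H](C)c1ccc(-c2ccccc2-c2nnn[nH]2)cc1`: 0.000975
- compound 3, `CCCCN(c1nc2c(CO)cccc2o1)[C@H](C)c1ccc(-c2ccccc2-c2nnn[nH]2)cc1`: 0.00112

In an ADME assay on the whole organism (plasma, Macaca fascicularis) for protein binding, read by LC-MS, using equilibrium dialysis and cassette dosing, with a stated time of 24 h, at a dose of 1 mg/kg by the oral route (on this read-out lower numbers stand for a smaller free fraction and higher numbers for a larger free fraction), compound 3 gives the highest of the three numbers. Its nearest neighbour is compound 2, with the pair lying within the scatter: a 1.1-fold higher number from compound 2 to compound 3 (0.06 log units; within the scatter). Compound 1 stands furthest away: a 3.9-fold higher number from compound 1 to compound 3 (0.59 log units; beyond the scatter).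

The next compound in the series is compound 4, `CCCCN(c1nc2c(C(=O)N(C)C)cccc2o1)[C@H](C)c1ccc(-c2ccccc2-c2nnn[nH]2)cc1`. Relative to compound 3 it differs in one place: dimethylcarbamoyl in place of hydroxymethyl on an aromatic carbon.

Going by the values given here, two measured steps bear on this change. The step of a 3.4-fold higher number from compound 1 to compound 2 (0.53 log units; beyond the scatter) shows that replacing the acid of compound 1 by a secondary amide raised the number modestly. The step of a 1.1-fold higher number from compound 2 to compound 3 (0.06 log units; within the scatter) shows that the secondary amide of compound 2 and the hydroxymethyl of compound 3 give numbers within the scatter of each other. The dimethylcarbamoyl of compound 4 is a tertiary amide; the step from compound 2 to compound 3 suggests that an amide here sits close to the hydroxymethyl, so no step beyond the scatter is expected in this assay, with a slight drift upward possible on the strength of the step from compound 1 to compound 2.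

Compound 4 is therefore expected to give about 0.0012 in this assay, estimated within 0.0005 to 0.0028, an expected step of a 1.1-fold higher number from compound 3 to compound 4 (0.03 log units; within the scatter).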

Compound 4, unbound fraction: 0.00411
Beside the measured number, compound 4's estimate is 3.4-fold (0.53 log units) below it, and the stated range ends below it.
By their numbers in this assay, from the lowest: compound 1; then compounds 2 and 3 (each within the scatter of the next); then compound 4.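

In this assay the amide at this position no longer tracks the hydroxymethyl once its nitrogen is fully substituted: methyl in place of hydrogen on the amide-type nitrogen gives a step beyond the scatter (a 4.2-fold higher number from compound 2 to compound 4 (0.62 log units; beyond the scatter)), whereas the secondary amide and the hydroxymethyl lay within the scatter of each other. The swap of hydroxymethyl for dimethylcarbamoyl on this aromatic carbon is also beyond the scatter (a 3.7-fold higher number from compound 3 to compound 4 (0.56 log units; beyond the scatter)), so the free fraction here depends on the kind of amide and not merely on the carboxy group being gone. Across the series the widest step now runs from the acid to the tertiary amide (a 14-fold higher number from compound 1 to compound 4 (1.16 log units; beyond the scatter)), and compound 4 holds the highest number of the four, though nothing at hand gives a reason for the effect of the added methyl.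

Still open, on these data alone, is whether the rise continues with larger groups on the amide nitrogen, such as diethylcarbamoyl or a pyrrolidine amide, and where a primary amide would fall relative to compound 2. A methoxymethyl group in place of the hydroxymethyl would show whether capping the oxygen with methyl gives a similar step to that seen on the amide nitrogen.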